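The source may report more compounds than this note shows. Statements on the series, on what has been measured and on what is new or still open speak of the compounds shown alone.

Measured so far:
- compound 1 `COc1cc(NC(C)CCCNC(=O)NNC(=O)Nc2ccc(F)cc2)c2ncccc2c1` gives > 100000 nM (a limit of the assay)
- compound 2 `COc1cc(NC(C)CCCNC(=O)NNC(=O)Nc2ccc(Cl)cc2)c2ncccc2c1` gives 63000 nM

Among the compounds with values here, in a functional assay on NCI-H460 cells (Homo sapiens) for inhibition, read by MTT assay, with a stated time of 72 h (a higher number here means a weaker inhibitor, a lower number a stronger inhibitor), compound 2 gives 63000 nM, and this is the only true number available so far. Compound 1 reads > 100000 nM and that entry is a limit, not a number.

The next compound, compound 3 `COc1cc(NC(C)CCCNC(=O)NNC(=O)Nc2ccc(C(F)(F)F)cc2)c2ncccc2c1`, keeps everything in compound 2 except one group: trifluoromethyl in place of chloro on an aromatic carbon, para to a large group (trifluoromethyl in place of chloro on an aromatic carbon).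

Within the data shown here, only one measured step bears on this change. It is a swap of one group on the same aromatic carbon, an at least 1.5-fold lower number from compound 1 to compound 2 (0.20 log units; that floor lies within the scatter). That step is small and rests on a limit, so it gives no firm direction for a new swap there. No step beyond the scatter is therefore expected in this assay, in either direction. The expected change is a 1.3-fold lower number from compound 2 to compound 3 (0.10 log units; within the scatter). Compound 3 could also return only a limit, as recorded in the limit of > 100000 nM in this assay, at which 1 of the 2 values shown sits. For compound 3 the estimated value is 50000 nM, within an expected range of 18000 nM to 100000 nM.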

Compound 3, half-maximal inhibitory concentration: 12000 nM
Compound 3: the middle estimate sits 4.2-fold (0.62 log units) above what was measured; measured number below the stated range.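

In this assay, within the data shown here, trifluoromethyl on this aromatic carbon, para to a large group, gives the first step at this place that clearly lies beyond the scatter, and compound 3 has the lowest number of the three compounds: a 5.3-fold lower number from compound 2 to compound 3 (0.72 log units; beyond the scatter). The earlier swap of chloro for fluoro gave no firm direction, whereas this result shows that the group on this carbon can shift the number measurably, and the comparison with fluoro points the same way, though only as a floor: an at least 8.3-fold lower number from compound 1 to compound 3 (0.92 log units; beyond the scatter). Compound 1 gives > 100000 nM, which is a limit of the assay and not a number, so the true size of that last step stays unknown: the limit of > 100000 nM in this assay, at which 1 of the 3 values shown sits.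

With only fluoro, chloro and trifluoromethyl shown, it remains open whether a nitrile, a methoxy group or a dimethylamino group on this carbon would lower the number further or raise it again. Also open, on these data alone, is whether trifluoromethyl on another carbon of the same ring, or a longer chain joining the core to this ring, would keep the gain seen with compound 3.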